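The compounds below may be only part of what the source reports. "The series", "measured", "known", "first", "only" and "open" are said of these compounds alone.

In a functional assay on NALM-6 cells (Homo sapiens) for cytotoxicity, read by luminescence and CellTiter-Glo, with a stated time of 3 days (on this read-out lower numbers stand for stronger inhibition and higher numbers for weaker inhibition), compound 1 (`N#Cc1cccc(NC(=O)c2cc(F)ccc2O)c1`) gave no number ("not determined" (no result reported)). Compound 2 (`O=C(Nc1ccc(Cl)c(Cl)c1)c1cc(F)ccc1O`) measured 1370 nM in the same test. Compound 3 (`O=C(Nc1cccc(C(F)(F)F)c1)c1cc(F)ccc1O`) measured 1800 nM and so stands within the scatter of compound 2, with no order to be drawn between the two.

Compound 4 (`O=C(Nc1ccc(Cl)c(C(F)(F)F)c1)c1cc(F)ccc1O`) differs from compound 3 in one place: chloro in place of hydrogen on an aromatic carbon, ortho to a trifluoromethyl group and para to a large group. Among the measured compounds shown here, no pair of measured compounds shows this change directly, so the evidence is thin. Compound 2 also carries chloro and gave a number (1370 nM) in the same range as compound 3 (1800 nM), which suggests no large shift. In this assay a modest move towards stronger inhibition is expected, of a size close to the scatter. The estimated step is a 1.8-fold lower number from compound 3 to compound 4 (0.26 log units; within the scatter) and may not be resolved from noise. For compound 4 the expected value is 1000 nM in an estimated range from 400 nM to 2500 nM in this test.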

Compound 4, half-maximal inhibitory concentration: 970 nM
Beside the measured number, compound 4's estimate is 1.0-fold (0.01 log units) above it; measured number inside the range.
By their numbers in this assay, from the lowest: compounds 4, 2 and 3 (each within the scatter of the next).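

In this assay, chloro in place of hydrogen on the aromatic carbon ortho to a trifluoromethyl group and para to a large group gives a 1.9-fold lower number from compound 3 to compound 4 (0.27 log units; within the scatter) and so shows that this position takes the chlorine with no change that can be told from the scatter. Trifluoromethyl in place of chloro on an aromatic carbon gives a 1.4-fold lower number from compound 2 to compound 4 (0.15 log units; within the scatter) and so leaves these two groups unresolved from each other in this test. Nothing measured among the compounds shown offers a reason for either result.

From the compounds shown here alone, whether an amine or a carboxylic acid on this carbon would give a step beyond the scatter stays open. So does whether a methoxy group there would differ from chloro.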